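A few compounds are considered here, and "the series" means these few. Any claim that something is new, unique, unknown or untested is made for them only; others in the source may bear on it.

In a functional assay on BHK-21 cells (Mesocricetus auratus) for antiproliferative activity, read by sulforhodamine B assay, with a stated time of 48 h, tested at 0.1 uM (on this read-out higher numbers stand for more inhibition of growth at the one concentration tested and lower numbers for less inhibition of growth), three compounds have been measured so far. Compound 1 `Cc1occc1-c1nn2c(-c3ccncc3)nnc2s1` gives 54.6%, and compound 2 `Fc1ccc(-c2nn3c(-c4ccncc4)nnc3s2)cc1Cl` gives 40.9%. Compound 3 `Fc1ccc(OCc2nn3c(-c4ccncc4)nnc3s2)cc1` gives 43.8%, a number within the scatter of compound 2 and beyond the scatter below compound 1. Compound 4 `COc1ccc(OCc2nn3c(-c4ccncc4)nnc3s2)cc1` carries methoxy in place of fluoro on an aromatic carbon, para to a large group: methoxy in place of fluoro on an aromatic carbon. Going by the values given here, no two measured compounds differ in one place only, so the data offer no direct guide to this change. In this assay, a step in neither direction beyond the scatter is therefore expected. The estimated step runs a number 2.2 percentage points higher from compound 3 to compound 4 (within the scatter). Compound 4 is expected at 46%, with an estimated range from 32% to 60%.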

Compound 4, percent growth inhibition at one concentration: 63.3%
Compound 4: middle estimate off by 17.3 percentage points, on the low side, and the stated range ends below it.
By their numbers in this assay, from the lowest: compounds 2 and 3 (each within the scatter of the next); then compounds 1 and 4 (each within the scatter of the next).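

In this assay, going by these compounds alone, methoxy in place of fluoro on an aromatic carbon, para to a large group, gives a number 19.5 percentage points higher from compound 3 to compound 4 (beyond the scatter) and is the first change in one place only. Within the data shown here, it shows that this position is not indifferent to the group it carries, which the earlier compounds, differing in more than one place, could not show. Nothing measured here explains the step. Going by these compounds, whether a hydroxy group, an amine or a longer alkoxy chain at this place would behave like methoxy stays open. So does whether the step would hold on another part of the molecule.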